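Two Aryl Groups on a Shared Core, One Still Unmeasured

The source may hold more compounds than are shown below. What is called first, only, known or untested is meant among the compounds shown, and "the series" means these compounds.

Going by the values given here, compound 2 `Cc1cc(NC(=O)Cn2nnc(-c3ccc(F)cc3)n2)n(C2CCCCC2)n1` is the compound with the lowest number among the two measured so far. In an assay on HEK293 cells for activation of Kir3.1/Kir3.2 (Homo sapiens), read by thallium flux (on this read-out lower numbers stand for an effect already at smaller amounts and higher numbers for an effect only at larger amounts of compound), compound 2 gives 180 nM. Compound 1 `Cc1cc(NC(=S)Cn2nnc(-c3ccccc3)n2)n(C2CCCCC2)n1` is the nearest measured neighbour; in this assay compound 1 gives 623 nM, a number that lies beyond the usual scatter above that of compound 2. The two compounds differ in more than one place, so their values alone say nothing about any single part of the structure.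

Compound 3 `Cc1cc(NC(=O)Cn2nnc(-c3ccc(Cl)c(C)c3)n2)n(C2CCCCC2)n1` has not yet been measured. It differs from compound 2 in one place: 4-chloro-3-methylphenyl in place of 4-fluorophenyl on an aromatic carbon. Among the compounds with values here, no measured pair shows the effect of such a change on this core, so any expectation rests on the value of compound 2 alone. A small step, in either direction, or none beyond the scatter, is expected from compound 2 to compound 3, a 1.2-fold higher number from compound 2 to compound 3 (0.09 log units; within the scatter). For compound 3 an estimate of 220 nM is given, expected to fall between 70 nM and 700 nM.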

Compound 3, half-maximal effective concentration: 712 nM
The estimate for compound 3 lay 3.2-fold (0.51 log units) below the measured number, outside the stated range (above it).
By their numbers in this assay, from the lowest: compound 2; then compounds 1 and 3 (each within the scatter of the next).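

In this assay, placing 4-chloro-3-methylphenyl instead of 4-fluorophenyl on the aromatic carbon of the five-membered aromatic ring with 4 nitrogen gives a 4.0-fold higher number from compound 2 to compound 3 (0.60 log units; beyond the scatter), the only step shown so far that isolates a single place on the shared core. The exchange keeps one six-membered aromatic ring of carbon only, adds no hydrogen-bond donors or acceptors and leaves the charge unchanged, yet the number still moves beyond the scatter, so this position does not accept every substituted phenyl group equally. No measurement shown accounts for this step, so its cause remains unknown.

The change replaces fluorine with chlorine and adds a methyl group at once, so a phenyl ring carrying only the chlorine or only the methyl would be needed to tell which part goes with the higher number. Also open, on these data alone, is how a group of another kind at this place, such as a phenyl ring bearing an amine or a carboxylic acid, would read in this assay.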